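From methoxy to methyl on a shared core

This account rests on a few compounds, and the source may have more. Where it says the series, first, only, none or still open, it means among the compounds named here.

compound 1 `COc1ccc(C2=C(c3ccc(SC)cc3)CC3CCCN3C2=O)cc1OC(=O)CNC(=O)OC(C)(C)C`: 6000 nM
compound 2 `CSc1ccc(C2=C(c3ccc(C)c(C)c3)C(=O)N3CCCC3C2)cc1`: 10000 nM
compound 3 `COc1ccc(C2=C(c3ccc(SC)cc3)CC3CCCN3C2=O)cc1`: 2000 nM

In a functional assay on U-251 cells (Homo sapiens) for cytotoxicity (a higher number here means a weaker inhibitor of growth, a lower number a stronger inhibitor of growth), compound 3 gives 2000 nM, the lowest of the three numbers, and its gaps to both other compounds lie beyond the scatter. Compound 4 `CSc1ccc(C2=C(c3ccc(C)cc3)C(=O)N3CCCC3C2)cc1` has not yet been measured. It differs from compound 3 by methyl in place of methoxy on an aromatic carbon, with methyl in place of methoxy on an aromatic carbon, para to a large group.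

Among the measured compounds shown here, no measured step compares these two groups directly. The closest is a 5.0-fold lower number from compound 2 to compound 3 (0.70 log units; beyond the scatter), where 4-methoxyphenyl stands in place of 3,4-dimethylphenyl. Compound 4 carries 4-methylphenyl there, so part of that modest step is expected to be lost. The other step, a 3.0-fold lower number from compound 1 to compound 3 (0.48 log units; beyond the scatter), concerns a different group and bears little on this change.

The expected change is a 2.5-fold higher number from compound 3 to compound 4 (0.40 log units; beyond the scatter), a rise in the number. For compound 4 the estimated value in this assay is 5000 nM, with an expected range from 2000 nM to 12000 nM.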

Compound 4, concentration for 50% growth inhibition: 400 nM
Compound 4: the middle estimate sits 13-fold (1.10 log units) above what was measured; the measured number lies below the stated range.
By their numbers in this assay, from the lowest: compound 4; then compound 3; then compounds 1 and 2 (each within the scatter of the next).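

Among the compounds shown here, replacing methoxy with methyl on this aromatic carbon, para to a large group, gives a 5.0-fold lower number from compound 3 to compound 4 (0.70 log units; beyond the scatter) in this assay, so the methyl group at this place does not cost growth inhibition as the earlier compounds had suggested. Taking away the other methyl of the 3,4-dimethylphenyl ring gives a 25-fold lower number from compound 2 to compound 4 (1.40 log units; beyond the scatter), which places the weak number of compound 2 on that extra methyl and not on the methyl that compound 4 keeps. The earlier step from compound 2 to compound 3 had changed both places on that ring at once and could not separate them.

Going by these compounds, with only methoxy and methyl compared on this carbon, it stays open how an ethyl group, a chlorine atom or an amine would fare there. Nothing available here accounts for the difference between methyl and methoxy at this place.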